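Removing an Aromatic Methyl: What Change to Expect

The source may hold more compounds than are shown below. What is called first, only, known or untested is meant among the compounds shown, and "the series" means these compounds.

Of the compounds shown here, two have so far been measured in an assay for inhibition of 3-hydroxy-3-methylglutaryl-coenzyme A reductase (Rattus norvegicus); a higher number here means a weaker inhibitor, a lower number a stronger inhibitor. Compound 1, `Cc1cc(-c2cc(Cl)cc(Cl)c2/C=C/[C@@H]2C[C@@H](O)CC(=O)O2)ccc1F`, gives 29 nM in this assay. Compound 2, `Cc1cc(Cl)c(/C=C/[C@@H]2C[C@@H](O)CC(=O)O2)c(-c2ccc(F)c(C)c2)c1`, gives 13 nM in this assay. Among the compounds with values here, compound 2 therefore holds the lower of the two numbers, and the single measured step, a 2.2-fold lower number from compound 1 to compound 2 (0.35 log units; beyond the scatter), separates it from compound 1 by a modest margin that lies beyond the usual scatter.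

Compound 3, `Cc1cc(-c2cccc(Cl)c2/C=C/[C@@H]2C[C@@H](O)CC(=O)O2)ccc1F`, has not been measured. It differs from compound 2 by hydrogen in place of methyl on an aromatic carbon. Within the data shown here, no measured step concerns exactly this exchange of a methyl for a hydrogen. Among the measured compounds shown here, the only step available, a 2.2-fold lower number from compound 1 to compound 2 (0.35 log units; beyond the scatter), changed a different aromatic substituent and was modest in size, so a change of at most similar size is all that the data support.

The step from compound 2 to compound 3 is expected to be small, estimated as a 1.9-fold higher number from compound 2 to compound 3 (0.28 log units; within the scatter), leaning toward a slightly higher number, because loss of the methyl undoes part of what the step of a 2.2-fold lower number from compound 1 to compound 2 (0.35 log units; beyond the scatter) gained. Compound 3 is expected to give about 25 nM in this assay, within a range from 10 nM to 60 nM.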

Compound 3, half-maximal inhibitory concentration: 30 nM
Beside the measured number, compound 3's estimate is 1.2-fold (0.08 log units) below it, and the stated range covers the measured number.
By their numbers in this assay, from the lowest: compound 2; then compounds 1 and 3 (each within the scatter of the next).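

Taking the methyl away, with a 2.3-fold higher number from compound 2 to compound 3 (0.36 log units; beyond the scatter) in this assay, costs a modest but real amount at this aromatic carbon, which lies meta to a chloro group and para to a large group. Hydrogen and chloro at the same carbon cannot be told apart, with a 1.0-fold higher number from compound 1 to compound 3 (0.01 log units; within the scatter) in this assay, so among the three groups now seen here, only the methyl stands apart. The earlier pair could not show this, since a difference between methyl and chloro alone does not say which of the two departs from the plain hydrogen, and here it is the methyl. No measurement shown here explains why the methyl differs from the other two groups.

As far as these compounds go, three small groups on one carbon give only a narrow view, so it remains open whether an ethyl, a methoxy or an amine at this place would lower the number further, leave it unchanged or raise it. From the compounds shown here alone, it is also open whether the methyl would keep its modest edge if the other chloro group or the 4-fluoro-3-methylphenyl group were changed.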